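A few compounds are considered here, and "the series" means these few. Any claim that something is new, unique, unknown or untested is made for them only; others in the source may bear on it.

In a functional assay on MCF7 cells (Homo sapiens) for antiproliferative activity, read by MTT assay, with a stated time of 48 h (on this read-out higher numbers stand for weaker inhibition and lower numbers for stronger inhibition), compound 3 `Cc1cc(C)cc(C(=O)Nc2cccc(/C=C/C(=O)c3nc4ccccc4[nH]3)c2)c1` gives 24600 nM, the highest of the three numbers shown; compound 1 `O=C(/C=C/c1cccc(NC(=O)c2ccccc2Cl)c1)c1nc2ccccc2[nH]1` gives 4570 nM and compound 2 `O=C(Nc1cccc(/C=C/C(=O)c2nc3ccccc3[nH]2)c1)c1cccc(Br)c1` gives 5210 nM. Compound 4 `O=C(/C=C/c1cccc(NS(=O)(=O)c2ccc(Cl)cc2)c1)c1nc2ccccc2[nH]1` differs from compound 3 by (4-chlorophenyl)sulfonyl in place of (3,5-dimethylphenyl)carbonyl on a nitrogen on an aromatic ring. Within the data shown here, two measured steps bear on this change: a 5.4-fold higher number from compound 1 to compound 3 (0.73 log units; beyond the scatter) and a 4.7-fold higher number from compound 2 to compound 3 (0.67 log units; beyond the scatter), both a weakening when a 2-chlorophenyl or 3-bromophenyl gives way to the 3,5-dimethylphenyl. Among the measured compounds shown here, compound 4 brings back a chlorine on the phenyl, yet no measured pair shows what exchanging a carbonyl for a sulfonyl does, so that part remains unknown. A modest gain is therefore expected, a 3.1-fold lower number from compound 3 to compound 4 (0.49 log units; beyond the scatter). Compound 4 is estimated at 8000 nM, with a range from 2500 nM to 25000 nM.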

Compound 4, half-maximal inhibitory concentration: 3820 nM
The estimate for compound 4 lay 2.1-fold (0.32 log units) above the measured number, and the stated range covers the measured number.
By their numbers in this assay, from the lowest: compounds 4, 1 and 2 (each within the scatter of the next); then compound 3.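

In this assay the carbonyl is not essential on this nitrogen: (4-chlorophenyl)sulfonyl recovers the number lost with (3,5-dimethylphenyl)carbonyl (a 6.4-fold lower number from compound 3 to compound 4 (0.81 log units; beyond the scatter)). It also sits level with the amides carrying a halogen (a 1.4-fold lower number from compound 2 to compound 4 (0.13 log units; within the scatter); a 1.2-fold lower number from compound 1 to compound 4 (0.08 log units; within the scatter)). The linker and the ring substituents change together, and nothing available explains the result.

Still open, as far as these compounds go, is how (4-chlorophenyl)carbonyl or (3,5-dimethylphenyl)sulfonyl would read, which would separate those two changes. Also open, from the compounds shown here alone, is what methylsulfonyl, with no phenyl ring, would give.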